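This account rests on a few compounds, and the source may have more. Where it says the series, first, only, none or still open, it means among the compounds named here.

Measured compounds:
Compound 1, `CN(C)CCC(OC(=O)c1ccc2ccccc2c1)c1ccc(Cl)cc1`, gives 49% in an assay on NIH3T3 cells with Urotensin-2 receptor (Homo sapiens) as the target; a lower number here means a smaller maximal response, a higher number a larger maximal response.
Compound 2, `CN(C)CCC(NC(=O)c1ccc(C(F)(F)F)cc1)c1ccc(Cl)cc1`, gives 115% in this assay.
Compound 3, `CN(C)CC[C@H](NC(=O)c1ccc2ccccc2c1)c1ccc(Cl)cc1`, gives 109% in this assay.

Compound 2 stands at the top of the three numbers: the nearest is compound 3, whose value sits within the scatter of it, and the furthest is compound 1, whose value lies beyond the scatter below it. Compound 1 is also the only ester of the three; the two amides give the larger responses.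

Compound 4, `CN(C)CCC(NC(=O)c1ccccc1)c1ccc(Cl)cc1`, is not yet measured. It differs from compound 2 in one place: hydrogen in place of trifluoromethyl on an aromatic carbon.

For the measured compounds named here, no measured pair tells how this change plays out, so the expectation rests on the values of compounds 2 and 3 and on the fact that both amides, with a large group on the aryl ring, reach the top of the range. A modest drop is expected for compound 4, as a step from a number 30 percentage points lower from compound 2 to compound 4 (beyond the scatter). For compound 4 the estimate is 85%, with a range from 50% to 115%.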

Compound 4, largest response reached (reported as efficacy), in percent of the reference or control that the assay uses: 158%
Beside the measured number, compound 4's estimate is 73 percentage points below it, and the stated range ends below it.
By their numbers in this assay, from the lowest: compound 1; then compounds 3 and 2 (each within the scatter of the next); then compound 4.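

In this assay, hydrogen in place of trifluoromethyl on the aromatic carbon para to a large group gives a number 43 percentage points higher from compound 2 to compound 4 (beyond the scatter), the first step read at this position. In this pair, a large maximal response does not depend on trifluoromethyl at this position, and the group's presence goes with the smaller number, not the larger one. Nothing at hand explains the size of this step.

One pair cannot show whether this step is specific to trifluoromethyl or would recur with any other group on this carbon, such as a fluorine, a chlorine, a methyl or a methoxy. Also open, going by these compounds, is how the response would shift with a methyl on the amide nitrogen or a longer chain to the dimethylamine.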